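Inverting the chain stereocentre of compound 2

The source may hold more compounds than are shown below. What is called first, only, known or untested is meant among the compounds shown, and "the series" means these compounds.

Measured in a physicochemical assay for solubility, measured as kinetic solubility; a lower number here means a less soluble compound, a higher number a more soluble compound:
compound 1 `Cc1cc(C)c(CN2CCc3c(Cl)cc(-c4c(C)noc4C)c(Cl)c3C2=O)c(=O)[nH]1`: 93000 nM
compound 2 `Cc1cc(C)c(CN2CCc3c(Cl)cc([C@H](C)CO)c(Cl)c3C2=O)c(=O)[nH]1`: 131000 nM

Compound 2 stands level with compound 1 within the scatter (a 1.4-fold higher number from compound 1 to compound 2 (0.15 log units; within the scatter)). Compound 3 `Cc1cc(C)c(CN2CCc3c(Cl)cc([C@@H](C)CO)c(Cl)c3C2=O)c(=O)[nH]1` keeps every atom and bond of compound 2: the two compounds have the same atoms and bonds and differ only in configuration as drawn: 1 of 1 stereo elements differ; a stereocentre at a saturated chain carbon is drawn S in compound 2 and R in compound 3 is the whole change. Among the measured compounds shown here, no measured step tests a change of configuration. For the measured compounds named here, the single measured step, a change of group, stayed within the scatter. No step beyond the scatter is therefore expected in this assay here, and the expected step is small (a 1.1-fold lower number from compound 2 to compound 3 (0.04 log units; within the scatter)). Compound 3 is estimated at 120000 nM (range 65000 nM to 200000 nM).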

Compound 3, solubility: 143000 nM
Beside the measured number, compound 3's estimate is 1.2-fold (0.08 log units) below it; low and high end bracket the measured number.
By their numbers in this assay, from the lowest: compounds 1, 2 and 3 (each within the scatter of the next).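

In this assay, a change of configuration at the saturated chain carbon is now tested, and the result, a 1.1-fold higher number from compound 2 to compound 3 (0.04 log units; within the scatter), shows no separation between the two drawn forms. The R form also stays level with the 3,5-dimethyl-1,2-oxazol-4-yl group of compound 1, with a 1.5-fold higher number from compound 1 to compound 3 (0.19 log units; within the scatter), as the S form did. The comparison isolates configuration alone: the fact that compounds 2 and 3 differ only in the configuration as drawn.

Open, from the compounds shown here alone, is whether an amine, a carboxylic acid or a longer chain at this position would give a step beyond the scatter. Also open, going by these compounds, is whether the two configurations stay level in any other assay.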